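A Nitro Group Replaces Chlorine on the Anilino Ring

The compounds below may be only part of what the source reports. "The series", "measured", "known", "first", "only" and "open" are said of these compounds alone.

Compound 3, `N#Cc1c(Nc2ccc(Cl)cc2)nc(SCc2cn(Cc3ccccc3Cl)nn2)nc1-c1ccccc1`, carries a 4-chlorophenyl on the anilino nitrogen of the shared core. In a functional assay on MGC-803 cells (Homo sapiens) for inhibition, read by MTT assay, with a stated time of 72 h (on this read-out higher numbers stand for weaker inhibition and lower numbers for stronger inhibition), compound 3 gives 5850 nM, the lowest of the two numbers recorded so far. Compound 1, `C#CCSc1nc(Nc2ccc(OC)cc2)c(C#N)c(-c2ccccc2)n1`, bears a 4-methoxyphenyl on the same nitrogen and gives 28400 nM in this assay, a number that lies above that of compound 3 by more than the scatter. Compound 2, `C#CCSc1nc(Nc2cccc(C(F)(F)F)c2)c(C#N)c(-c2ccccc2)n1`, with a 3-trifluoromethylphenyl there, gives > 128000 nM, which is a limit of this assay and not a number (the limit of > 128000 nM in this assay, at which 1 of the 3 values shown sits).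

Compound 4, `N#Cc1c(Nc2cccc([N+](=O)[O-])c2)nc(SCc2cn(Cc3ccccc3Cl)nn2)nc1-c1ccccc1`, has not yet been measured. It differs from compound 3 in one place: 3-nitrophenyl in place of 4-chlorophenyl on a nitrogen on an aromatic ring. Among the compounds with values here, no pair of measured compounds shows exactly this exchange, so the size of the step can only be guessed from the values at hand, where compound 1 sits above compound 3 and compound 2 reaches only a limit. The author expects the step from compound 3 to compound 4 to be a 2.1-fold higher number from compound 3 to compound 4 (0.31 log units; beyond the scatter), towards weaker inhibition, while allowing that it may fall within the scatter. For compound 4 the estimate in this assay is 12000 nM, with a range from 3000 nM to 50000 nM.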

Compound 4, half-maximal inhibitory concentration: 43100 nM
Beside the measured number, compound 4's estimate is 3.6-fold (0.56 log units) below it; measured number inside the range.
By their numbers in this assay, from the lowest: compound 3; then compounds 1 and 4 (each within the scatter of the next). At a limit, above all of these: compound 2.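

Within the data shown here, the exchange of 4-chlorophenyl for 3-nitrophenyl on a nitrogen on an aromatic ring is the first change in this set that can be read on its own: in this assay it brings a 7.4-fold higher number from compound 3 to compound 4 (0.87 log units; beyond the scatter), towards weaker inhibition. Among these compounds, with the rest of the molecule held the same, the group on this nitrogen therefore moves the number by more than the scatter, something the earlier compounds, which differ in more than one place, could not show. Nothing measured here gives a reason for this step.

The single step changes both the substituent and where it stands on the phenyl ring, so the compounds shown leave open whether the weaker inhibition goes with the nitro group or with its place, a question that a 4-nitrophenyl or a 3-chlorophenyl on the same nitrogen would help to settle. Also open, as far as these compounds go, is how an aminophenyl or an unsubstituted phenyl would read at this position, and whether the order of compound 3 and compound 4 would hold with a different group on the rest of the shared core.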